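This account rests on a few compounds, and the source may have more. Where it says the series, first, only, none or still open, it means among the compounds named here.

Within the data shown here, compound 1 `Cc1cn([C@@H]2O[C@H](CO[Si](C)(C)C(C)(C)C)[C@@]3(OS(=O)(=O)C=C3N)[C@H]2O[Si](C)(C)C(C)(C)C)c(=O)n(CC(N)=O)c1=O` gives 13300 nM in a functional assay on CCRF-CEM cells (Homo sapiens) (a higher number here means that more compound is tolerated, a lower number that less compound is tolerated), the lowest of the two numbers known, with compound 2 `Cc1cn([C@@H]2O[C@H](CO[Si](C)(C)C(C)(C)C)[C@@]3(OS(=O)(=O)C=C3N)[C@H]2O[Si](C)(C)C(C)(C)C)c(=O)n(CC(=O)N(C)C)c1=O` standing an 18-fold higher number from compound 1 to compound 2 (1.27 log units; beyond the scatter) away at 245000 nM. Compound 3 `Cc1cn([C@@H]2O[C@H](CO[Si](C)(C)C(C)(C)C)[C@@]3(OS(=O)(=O)C=C3N)[C@H]2O[Si](C)(C)C(C)(C)C)c(=O)n(C/C=C/CO)c1=O` differs from compound 1 by 3-hydroxyprop-1-en-1-yl in place of carbamoyl on a saturated chain carbon bound to an aromatic nitrogen. Among the measured compounds shown here, the only measured step, an 18-fold higher number from compound 1 to compound 2 (1.27 log units; beyond the scatter), altered the same chain at a different point, so it bears on this change only loosely; it does show that the group at this position matters. A higher number for compound 3 is therefore expected, with wide uncertainty, and the estimated step is a 3.0-fold higher number from compound 1 to compound 3 (0.48 log units; beyond the scatter). Compound 3 is estimated at 40000 nM, within 8000 nM to 200000 nM.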

Compound 3, half-maximal cytotoxic concentration: 4410 nM
The estimate for compound 3 lay 9.1-fold (0.96 log units) above the measured number; the measured number lies below the stated range.
By their numbers in this assay, from the lowest: compound 3; then compound 1; then compound 2.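

In this assay, the 3-hydroxyprop-1-en-1-yl group in place of carbamoyl on a saturated chain carbon bound to an aromatic nitrogen moved the number down rather than up (a 3.0-fold lower number from compound 1 to compound 3 (0.48 log units; beyond the scatter)). In place of dimethylcarbamoyl, the same group gave a far larger drop (a 56-fold lower number from compound 2 to compound 3 (1.74 log units; beyond the scatter)), so changes here can move the number in either direction from compound 1. Nothing available explains these steps. The compounds shown leave open whether the hydroxyl or the double bond of the 4-hydroxybut-2-en-1-yl chain matters. A saturated 4-hydroxybutyl chain, or an amine in place of that hydroxyl, would separate the two.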